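GPR88 agonists: swapping the distal phenyl substituent

This account rests on a few compounds, and the source may have more. Where it says the series, first, only, none or still open, it means among the compounds named here.

Measured so far:
Compound 1, `NC1(CN(C(=O)[C@@H]2C[C@H]2c2ccccc2)c2ccc(-c3ccccc3)cc2)CCCC1`: 0.57 nM
Compound 2, `CC[C@H](C)[C@H](N)CN(C(=O)[C@@H]1C[C@H]1c1cccc(OC)c1)c1ccc(-c2ccccc2)cc1`: 3000 nM
Compound 3, `CC[C@H](C)[C@H](N)CN(C(=O)[C@@H]1C[C@H]1c1ccccc1)c1ccc(-c2ccc(C(C)(C)C)cc2)cc1`: 750 nM

In a functional assay for agonist activity at G protein-coupled receptor 88 (Homo sapiens), read by HTRF and cAMP accumulation (a lower number here means that less compound is needed, a higher number that more compound is needed for the effect), compound 3 gives 750 nM, the second highest of the three numbers. Its nearest neighbour is compound 2, whose number is higher; the furthest is compound 1, whose number is far lower.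

Compound 4, `CC[C@H](C)[C@H](N)CN(C(=O)[C@@H]1C[C@H]1c1ccccc1)c1ccc(-c2ccc(OC(F)(F)F)cc2)cc1`, has not been measured. It differs from compound 3 in one place: trifluoromethoxy in place of tert-butyl on an aromatic carbon. For the measured compounds named here, no pair of measured compounds shows this change, so its effect is unknown here. The step of a 1.3-fold lower number from compound 3 to compound 4 (0.10 log units; within the scatter) is expected to stay within or close to the scatter, with no clear direction. Compound 4 is therefore estimated at 600 nM, within 150 nM to 2500 nM.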

Compound 4, half-maximal effective concentration: 170 nM
Estimate against measurement, compound 4: 3.5-fold (0.55 log units) above, within the range that was stated.
By their numbers in this assay, from the lowest: compound 1; then compound 4; then compound 3; then compound 2.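

In this assay, the change at this aromatic carbon gives a 4.4-fold lower number from compound 3 to compound 4 (0.64 log units; beyond the scatter), so the position is sensitive to which group it carries, and two non-ring groups of similar size can give clearly different numbers. Trifluoromethoxy brings one hydrogen-bond acceptor that tert-butyl lacks, but no measurement shown accounts for the step. As far as these compounds go, it remains open how a chlorine atom, a methoxy group or an amine at this carbon would compare, and whether trifluoromethoxy would give a similar step on the core of compound 1.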